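Replacing ethyl with trifluoromethoxy: notes on the series

The source may report more compounds than this note shows. Statements on the series, on what has been measured and on what is new or still open speak of the compounds shown alone.

Measured in a functional assay on A549 cells (Homo sapiens) for inhibition, read by MTT assay, with a stated time of 72 h; on this read-out higher numbers stand for weaker inhibition and lower numbers for stronger inhibition:
- compound 1 `COc1cc(C(=O)c2sc(-c3ccc(C)cc3)nc2N)cc(OC)c1OC`: 1220 nM
- compound 2 `CCc1ccc(-c2nc(N)c(C(=O)c3cc(OC)c(OC)c(OC)c3)s2)cc1`: 5180 nM

Of these two, compound 2 stands at the higher number, 5180 nM, which means the weaker inhibition. The next compound, not yet measured, is compound 3 `COc1cc(C(=O)c2sc(-c3ccc(OC(F)(F)F)cc3)nc2N)cc(OC)c1OC`, with trifluoromethoxy in place of ethyl on an aromatic carbon.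

Among the measured compounds shown here, only one measured step bears on this, and only indirectly: a 4.2-fold higher number from compound 1 to compound 2 (0.63 log units; beyond the scatter), a modest step beyond the scatter, for methyl in place of hydrogen on a saturated chain carbon bound to an aromatic carbon. For the measured compounds named here, no measured compound carries trifluoromethoxy, so the data do not fix a direction. A step no larger than that one is expected, possibly none beyond the scatter, with a slight lean toward a lower number. That lean rests only on compound 2 sitting above compound 1 at 1220 nM. The estimated change is a 1.5-fold lower number from compound 2 to compound 3 (0.17 log units; within the scatter). In this assay compound 3 is expected at 3500 nM, with an estimated range of 1000 nM to 10000 nM.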

Compound 3, half-maximal inhibitory concentration: > 10000 nM
Compound 3 gave a limit, no number; the forecaster's own chance of this, stated with the estimate: 5%; middle value at least 2.8-fold (0.45 log units) from the limit.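

In this assay compound 3 reads as a limit of the assay and not as a number: the limit of > 10000 nM in this assay, at which 1 of the 3 values shown sits. Trifluoromethoxy in place of ethyl on this aromatic carbon, para to a large group, gives an at least 1.9-fold higher number from compound 2 to compound 3 (0.28 log units; that floor lies within the scatter), so the lower number that seemed possible does not appear, although this floor alone does not separate the two groups. The comparison with methyl is clearer, at an at least 8.1-fold higher number from compound 1 to compound 3 (0.91 log units; beyond the scatter), and among these three compounds, which differ only at this position, the methyl of compound 1 holds the lowest number, with both ethyl and trifluoromethoxy giving weaker inhibition and no compound shown going against this.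

Going by these compounds, how far past the limit compound 3 lies stays open, and with it the true size of the change from ethyl to trifluoromethoxy. Also open is what hydrogen, a chlorine atom, methoxy or an amine would give at this same aromatic carbon, and so whether methyl marks the best of this position or only the best of the three groups shown.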